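Swapping chloro for hydroxy in compound 3

The source may hold more compounds than are shown below. What is called first, only, known or untested is meant among the compounds shown, and "the series" means these compounds.

For the measured compounds named here, three related compounds so far have numbers in a functional assay on SW-620 cells (Homo sapiens) for cytotoxicity, read by MTT assay, with a stated time of 72 h; a lower number here means a stronger inhibitor, a higher number a weaker inhibitor. Compound 3 (`COc1ccc(/C=C2\CCC/C(=C\c3ccc(Cl)cc3)C2=O)cc1OC`) gives 5900 nM. Compound 1 (`COc1cccc(/C=C2\CCC/C(=C\c3ccc(Br)cc3)C2=O)c1OC`) gives 11100 nM, which lies within the usual scatter of compound 3, so the two cannot be told apart. Compound 2 (`COc1cccc(/C=C2\CCC/C(=C\c3ccc(O)c(Cl)c3)C2=O)c1OC`) gives 16800 nM, a higher number than that of compound 3 and beyond the scatter. Compound 3 therefore shares the low end of this small set with compound 1.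

Compound 4 (`COc1ccc(/C=C2\CCC/C(=C\c3ccc(O)cc3)C2=O)cc1OC`) matches compound 3 except for one group: hydroxy in place of chloro on an aromatic carbon. In words, hydroxy takes the place of chloro on an aromatic carbon, turning 4-chlorophenyl into 4-hydroxyphenyl. Going by the values given here, only one measured step bears on this: a 1.5-fold higher number from compound 1 to compound 2 (0.18 log units; within the scatter), where a ring carrying bromo gives way to one carrying hydroxy and chloro. It is an imperfect guide, as that ring keeps a chloro and the other side of the core differs from compound 3. A change beyond the scatter is therefore not expected in this assay, although a small rise seems the likelier direction. The expected move is a 1.4-fold higher number from compound 3 to compound 4 (0.13 log units; within the scatter). Compound 4 is estimated at 8000 nM, with an expected range from 3500 nM to 18000 nM.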

Compound 4, half-maximal inhibitory concentration: 7700 nM
Estimate against measurement, compound 4: 1.0-fold (0.02 log units) above; low and high end bracket the measured number.
By their numbers in this assay, from the lowest: compounds 3, 4, 1 and 2 (each within the scatter of the next, the first and the last beyond it).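

Exchanging chloro for hydroxy on this aromatic carbon gives a 1.3-fold higher number from compound 3 to compound 4 (0.12 log units; within the scatter) in this assay, so compound 3 and compound 4 cannot be told apart in this assay. Unlike the earlier step between compound 1 and compound 2, where the ring gained a chloro as well as a hydroxy, this pair differs in one group only, so the reading belongs to this single exchange on an otherwise unchanged molecule. Chloro counts as neither a hydrogen-bond donor nor an acceptor while hydroxy counts as both, yet that difference leaves the two compounds within the scatter here, and no other measurement on hand says why they read alike.

What the compounds shown leave open is whether this aromatic carbon accepts any group in the same way, since an amine, a carboxylic acid or a longer chain such as butoxy could behave quite differently from chloro and hydroxy. From the compounds shown here alone, it is also open whether the same exchange would read alike on the core of compound 1, where the methoxy groups sit differently.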